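Compound 4 and the pyrimidin-5-yl to 4-chloropyrimidin-2-yl change

This account rests on a few compounds, and the source may have more. Where it says the series, first, only, none or still open, it means among the compounds named here.

Compound 1 `C[C@@H](Cn1ccc(-c2ccc(C#N)c(Cl)c2)n1)NC(=O)C1CC(=O)C1` gives 3040 nM in a functional assay on LNCaP cells (Homo sapiens) for antiproliferative activity, read by CCK-8 assay, with a stated time of 6 days; on this read-out lower numbers stand for stronger inhibition and higher numbers for weaker inhibition.
Compound 2 `C[C@@H](Cn1ccc(-c2ccc(C#N)c(Cl)c2)n1)NS(=O)(=O)c1cccnc1` gives 6140 nM in this assay.
Compound 3 `C[C@@H](Cn1ccc(-c2ccc(C#N)c(Cl)c2)n1)Nc1cncnc1` gives 2070 nM in this assay.

Among these three, compound 3 has the lowest number: a 1.5-fold lower number from compound 1 to compound 3 (0.17 log units; within the scatter) lies within the scatter, while a 3.0-fold lower number from compound 2 to compound 3 (0.47 log units; beyond the scatter) lies beyond it. Compound 4 `C[C@@H](Cn1ccc(-c2ccc(C#N)c(Cl)c2)n1)Nc1nccc(Cl)n1` differs from compound 3 in one place: 4-chloropyrimidin-2-yl in place of pyrimidin-5-yl on an amine nitrogen. Among the measured compounds shown here, no measured step exchanges one such ring for another; the measured steps, including a 2.0-fold higher number from compound 1 to compound 2 (0.31 log units; beyond the scatter), exchange groups of quite different kinds on that nitrogen and remained modest throughout. The expectation in this assay is therefore a step of no size beyond the scatter, a 1.3-fold lower number from compound 3 to compound 4 (0.11 log units; within the scatter). Compound 4 is estimated at 1600 nM, with a range from 500 nM to 5000 nM.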

Compound 4, half-maximal inhibitory concentration: 1400 nM
Beside the measured number, compound 4's estimate is 1.1-fold (0.06 log units) above it; the range from low to high includes it.
By their numbers in this assay, from the lowest: compounds 4, 3 and 1 (each within the scatter of the next, the first and the last beyond it); then compound 2.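

In this assay, among the compounds shown here, the only exchange of one such ring for another on this amine nitrogen, 4-chloropyrimidin-2-yl in place of pyrimidin-5-yl, stays within the scatter, with a 1.5-fold lower number from compound 3 to compound 4 (0.17 log units; within the scatter), so the two rings are not told apart here. Against the groups of other kinds, compound 4 stands clear of both, with a 4.4-fold lower number from compound 2 to compound 4 (0.64 log units; beyond the scatter) and a 2.2-fold lower number from compound 1 to compound 4 (0.34 log units; beyond the scatter), whereas compound 3 stayed within the scatter of compound 1. No evidence is available on why the numbers fall this way.

The compounds shown leave open how much of this small step belongs to the chlorine and how much to the change from pyrimidin-5-yl to a pyrimidin-2-yl ring. They also leave open whether an amine or a methoxy group in place of that chlorine would shift the number.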